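Hydrogen replaces trifluoromethyl in compound 4

A few compounds are considered here, and "the series" means these few. Any claim that something is new, unique, unknown or untested is made for them only; others in the source may bear on it.

In an ADME assay on microsomes from liver (Rattus norvegicus, strain Sprague-Dawley) for metabolic stability, read by LC-MS, with a stated time of 15 min, tested at 20 uM (a higher number here means that more of the compound is left, a lower number that less of the compound is left), compound 3 `O=C(Oc1ccccc1C(F)(F)F)c1coc(-c2ccccc2)n1` gives 10.7%. Compound 1 `CCC(=O)c1ccccc1OC(=O)c1coc(-c2ccccc2)n1` gives 8.7% and compound 2 `CCC(C)c1ccccc1OC(=O)c1coc(-c2ccccc2)n1` gives 8.3%, so all three stand together within the scatter. Compound 4 `O=C(Oc1ccccc1)c1coc(-c2ccccc2)n1` has hydrogen in place of trifluoromethyl on an aromatic carbon. Three measured exchanges on that aromatic carbon bear on this change: a number 0.4 percentage points lower from compound 1 to compound 2 (within the scatter), a number 2 percentage points higher from compound 1 to compound 3 (within the scatter) and a number 2.4 percentage points higher from compound 2 to compound 3 (within the scatter). Each stays within the scatter, although none of them leaves hydrogen there, so the evidence is indirect. No step beyond the scatter is expected, and the estimated step is a number 0.7 percentage points lower from compound 3 to compound 4 (within the scatter). For compound 4 the estimated value is 10%, with an expected range of 3% to 22%.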

Compound 4, percent of the compound remaining: 0.2%
Beside the measured number, compound 4's estimate is 9.8 percentage points above it, outside the stated range (below it).
By their numbers in this assay, from the lowest: compounds 4, 2, 1 and 3 (each within the scatter of the next, the first and the last beyond it).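

Going by these compounds alone, on this aromatic carbon, the exchanges among trifluoromethyl, sec-butyl and propanoyl had all stayed within the scatter, whereas hydrogen gives the first step beyond it in this assay, namely a number 10.5 percentage points lower from compound 3 to compound 4 (beyond the scatter). The other two steps, a number 8.1 percentage points lower from compound 2 to compound 4 (within the scatter) and a number 8.5 percentage points lower from compound 1 to compound 4 (within the scatter), stay within the scatter, so hydrogen is set apart from trifluoromethyl alone.

Nothing available explains this difference between hydrogen and trifluoromethyl. As far as these compounds go, whether a methyl group, a fluorine atom or an amine on this carbon would stand with compound 3 or with compound 4 remains open.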